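A fluoro added to compound 2

The source may report more compounds than this note shows. Statements on the series, on what has been measured and on what is new or still open speak of the compounds shown alone.

Compound 1 `COc1ccc(NC(=O)c2cc(=O)[nH]c3cc(Br)ccc23)cc1`: > 20000 nM
Compound 2 `O=C(Nc1cccc(F)c1)c1cc(=O)[nH]c2cc(-c3ccccc3)ccc12`: > 20000 nM

In a functional assay on KYSE-410 cells (Homo sapiens) for antiproliferative activity, read by MTT assay, with a stated time of 72 h (on this read-out lower numbers stand for stronger inhibition and higher numbers for weaker inhibition), compound 2 gives > 20000 nM, which is a limit and not a number. Compound 2 thus stands with compound 1 at the limit of > 20000 nM in this assay, at which 2 of the 2 values shown sit. Compound 3 `O=C(Nc1cccc(F)c1)c1cc(=O)[nH]c2cc(-c3ccc(F)cc3)ccc12` changes one place of compound 2: fluoro in place of hydrogen on an aromatic carbon. This is phenyl to 4-fluorophenyl, with fluoro in place of hydrogen on an aromatic carbon. Going by the values given here, no measured pair shows the size of such a change. In this assay the expected step that the limit leaves unreadable from compound 2 to compound 3 stays within the scatter, in no particular direction. Compound 3 is estimated at 25000 nM, with an expected range of 10000 nM to 50000 nM.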

Compound 3, half-maximal inhibitory concentration: 10300 nM
Beside the measured number, compound 3's estimate is 2.4-fold (0.39 log units) above it; measured number inside the range.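

In this assay, going by these compounds alone, compound 3 is the first compound here to give a number instead of a limit. The change from phenyl to 4-fluorophenyl gives an at least 1.9-fold lower number from compound 2 to compound 3 (0.28 log units; that floor lies within the scatter), and the true step may be larger, since compound 2 has only a limit, but the part that can be read does not clear the usual scatter. The other two compounds remain at a limit: the limit of > 20000 nM in this assay, at which 2 of the 3 values shown sit.

Still open, on these data alone, is whether a chloro, a methyl or an amine in place of that hydrogen would lower the number further or raise it.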